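The compounds below may be only part of what the source reports. "The series", "measured", "known", "first", "only" and "open" are said of these compounds alone.

The measured compounds: compound 1, `CCCCCCCc1nc(-c2ccc([C@@H](NC(=O)[C@H]3NCC[C@@H]3O)C(C)C)cc2)no1`, gives 3 ug/mL in a physicochemical assay for solubility, at pH 7.4; on this read-out lower numbers stand for lower solubility and higher numbers for higher solubility. Compound 2, `O=C(NCc1ccc(-c2noc(C3CCCCCC3)n2)cc1)[C@H]1NCC[C@@H]1O`, returns only a limit in this assay, > 50 ug/mL.

Within the data shown here, compound 1 thus holds the only number reported; the other value is the limit of > 50 ug/mL in this assay, at which 1 of the 2 values shown sits. Compound 3, `CCCCCCCc1nc(-c2ccc([C@H](CC)NC(=O)[C@H]3NCC[C@@H]3O)cc2)no1`, differs from compound 1 by hydrogen in place of methyl on a saturated chain carbon bound to two saturated chain carbons. Among the measured compounds shown here, no measured pair shows this change, so the step from compound 1 to compound 3 is expected to be small and upward, likely within the scatter of repeated measurements. Compound 3 is estimated at 5 ug/mL, between 2 ug/mL and 12 ug/mL. The expected step is a 1.7-fold higher number from compound 1 to compound 3 (0.22 log units; within the scatter).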

Compound 3, solubility: 9 ug/mL
For compound 3 the middle estimate is 1.8-fold (0.26 log units) below the measured one; the range from low to high includes it.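

Going from isopropyl to ethyl in this assay gives a 3.0-fold higher number from compound 1 to compound 3 (0.48 log units; beyond the scatter) on the shared core. Among these compounds, this is the first reading of a single change at this place, and it shows that removing one methyl on a saturated chain carbon bound to two saturated chain carbons can move the number beyond the scatter. No information given here bears on the cause of this step. From the compounds shown here alone, whether a longer chain or an amine at this place would move the number further remains open, as does whether the same change would give a similar step on another core.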